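From Sulfamoyl to Methyl on the Aromatic Ring

This account rests on a few compounds, and the source may have more. Where it says the series, first, only, none or still open, it means among the compounds named here.

Three measured compounds share one core and differ only in the group on the aromatic ring. Compound 1 `CCOC(=O)c1c(Nc2ccc(OC)cc2)ncnc1NC(C)C` carries methoxy, compound 2 `CCOC(=O)c1c(Nc2ccc([N+](=O)[O-])cc2)ncnc1NC(C)C` carries nitro, and compound 3 `CCOC(=O)c1c(Nc2ccc(S(N)(=O)=O)cc2)ncnc1NC(C)C` carries sulfamoyl. In a functional assay on the whole organism with Rattus norvegicus as the target, at a dose of 50 mg/kg by the oral route (on this read-out higher numbers stand for more inhibition at the one dose given (going by the name of the read-out) and lower numbers for less inhibition), compound 1 gives 62.7%, compound 2 gives 84.6%, and compound 3 gives 87.7%. Compound 3 is set apart from compound 1 by a number 25 percentage points higher from compound 1 to compound 3 (beyond the scatter), while against compound 2 the difference a number 3.1 percentage points higher from compound 2 to compound 3 (within the scatter) lies within the scatter, so those two cannot be told apart.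

Compound 4 `CCOC(=O)c1c(Nc2ccc(C)cc2)ncnc1NC(C)C` is the next step: methyl in place of sulfamoyl on an aromatic carbon. Among the measured compounds shown here, no measured step swaps sulfamoyl for methyl directly. The nearest guides are a number 25 percentage points higher from compound 1 to compound 3 (beyond the scatter) and a number 21.9 percentage points higher from compound 1 to compound 2 (beyond the scatter), which show that putting a four-heavy-atom group in place of methoxy raised the number well beyond the scatter. Methyl brings a single heavy atom, so the expectation is a drop back toward the level of compound 1. Compound 4 is therefore estimated at 65%, within 45% to 82%, an expected step of a number 22.7 percentage points lower from compound 3 to compound 4 (beyond the scatter).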

Compound 4, a percentage reported as inhibition, in the whole organism at one dose (the size of the read-out at that dose, not a potency): 89.7%
Beside the measured number, compound 4's estimate is 24.7 percentage points below it; the whole stated range lies below it.
By their numbers in this assay, from the lowest: compound 1; then compounds 2, 3 and 4 (each within the scatter of the next).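

In this assay replacing sulfamoyl, with 4 heavy atoms and its hydrogen-bond donor and acceptors, by methyl, with 1 heavy atom and neither, gives a number 2 percentage points higher from compound 3 to compound 4 (within the scatter) so among these compounds neither the heavy-atom count nor those donors and acceptors sort the results at this aromatic carbon. Methyl in place of nitro gives a number 5.1 percentage points higher from compound 2 to compound 4 (within the scatter) while methyl in place of methoxy gives a number 27 percentage points higher from compound 1 to compound 4 (beyond the scatter) and this leaves methoxy as the only one of the four groups set apart from the others. Nothing measured here explains what sets methoxy apart.

On these data alone, it remains open whether an amine or a carboxylic acid on this aromatic carbon would match compound 2, compound 3 and compound 4 or fall back toward compound 1. The same question holds for a longer chain such as butyl in place of methyl.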